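The source may report more compounds than this note shows. Statements on the series, on what has been measured and on what is new or still open speak of the compounds shown alone.

Working notes on the series. Compound 1 `C=C1C(=O)[C@]23C[C@@]1(O)CC[C@H]2c1ccc(OS(=O)(=O)c2ccc(C)cc2)c(C)c1[C@@H]3Cn1cc(-c2ccccn2)nn1` and compound 2 `C=C1C(=O)[C@]23C[C@@]1(O)CC[C@H]2c1ccc(O)c(C)c1[C@@H]3Cn1cc(-c2ccccn2)nn1` share one core; compound 3 `Cc1ccc(-c2cn(C[C@H]3c4c(ccc(O)c4C)[C@@H]4CC[C@@]5(C)C[C@]43CC5=O)nn2)cc1` and compound 4 `Cc1ccc(-c2cn(C[C@H]3c4c(ccc(OS(=O)(=O)c5ccc(C)cc5)c4C)[C@@H]4CC[C@@]5(C)C[C@]43CC5=O)nn2)cc1` share another, and the difference between the two cores is not broken down here. In a functional assay on HL-60 cells (Homo sapiens) for cytotoxicity, read by MTT assay, with a stated time of 4 days (a higher number here means a weaker inhibitor, a lower number a stronger inhibitor), compound 1 gives 1810 nM. In this assay compound 2 gives 1970 nM. The change that turns compound 2 into compound 1 is (4-methylphenyl)sulfonyl in place of hydrogen on an oxygen on an aromatic ring, and it made a 1.1-fold lower number from compound 2 to compound 1 (0.04 log units; within the scatter). For compound 3 only a limit is known: in this assay compound 3 gives > 20000 nM, which is a limit of the assay and not a number, namely (the limit of > 20000 nM in this assay, at which 1 of the 3 values shown sits). Compound 4 arises from compound 3 by the same change, ((4-methylphenyl)sulfonyl in place of hydrogen on an oxygen on an aromatic ring), made on the second core. Since the change appears only twice among these compounds, the one measured instance is the only guide. The expected step is a step that the limit leaves unreadable from compound 3 to compound 4, resting on a 1.1-fold lower number from compound 2 to compound 1 (0.04 log units; within the scatter) in the measured pair. Compound 4 is accordingly estimated at 30000 nM, with a likely range from 10000 nM to 100000 nM, and quite possibly again only a limit.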

Compound 4, half-maximal inhibitory concentration: > 20000 nM
Compound 4: only a limit was reported (the forecaster's own chance of this, stated with the estimate: 70%); the middle value does not contradict the limit.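

In this assay, compound 3 and compound 4 both stand at a limit of the assay and not at a number, so no step can be read between them: the limit of > 20000 nM in this assay, at which 2 of the 4 values shown sit.

The compounds shown leave open whether hydroxy to ((4-methylphenyl)sulfonyl)oxy has any size of effect on the core of compound 3.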